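The source may hold more compounds than are shown below. What is called first, only, known or untested is meant among the compounds shown, and "the series" means these compounds.

Values in a functional assay on MCF7 cells (Homo sapiens) for antiproliferative activity; a higher number here means a weaker inhibitor, a lower number a stronger inhibitor:
compound 1 `CCCN(CCC)CCCOc1ccc2cc(NC(=O)c3ccc(O)c(CC=C(C)C)c3)c(=O)oc2c1C`: > 50000 nM (a limit, not a number)
compound 2 `CC(C)=CCc1cc(C(=O)Nc2cc3ccc(OCCCN(C)C4CCCCC4)c(C)c3oc2=O)ccc1O`: 1080 nM

Going by the values given here, compound 2 holds the only true number so far, 1080 nM. Compound 1 is reported only as a limit, (the limit of > 50000 nM in this assay, at which 1 of the 2 values shown sits).

Compound 3 `CC(C)=CCc1cc(C(=O)Nc2cc3ccc(OCCCNc4ccccc4)c(C)c3oc2=O)ccc1O` carries anilino in place of cyclohexyl(methyl)amino on a saturated chain carbon, three bonds along the chain from an oxygen on an aromatic ring.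

Among the compounds with values here, one measured step bears on this, an at least 46-fold lower number from compound 1 to compound 2 (1.66 log units; beyond the scatter). It is large and falls at the same place, so this assay has responded strongly to the group there. That step is a different exchange, however, and gives the direction only loosely. Compound 2 is the better of the two compounds, so a loss is more likely than a gain, and the expected step is a 5.6-fold higher number from compound 2 to compound 3 (0.74 log units; beyond the scatter), moderate and beyond the scatter.

The estimate for compound 3 is 6000 nM, with an expected range of 1000 nM to 40000 nM.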

Compound 3, half-maximal inhibitory concentration: > 50000 nM
Compound 3 gave a limit, no number (the forecaster's own chance of this, stated with the estimate: 30%); at least 8.3-fold (0.92 log units) between middle value and limit.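

In this assay, anilino does not hold the level of cyclohexyl(methyl)amino on a saturated chain carbon, three bonds along the chain from an oxygen on an aromatic ring: an at least 46-fold higher number from compound 2 to compound 3 (1.66 log units; beyond the scatter). With three groups now tested at this place, only cyclohexyl(methyl)amino in compound 2 gives a true number, while dipropylamino in compound 1 and anilino in compound 3 do not. Compound 3 is reported only as a limit, and the step from compound 1 to compound 3 cannot be read, as both values are limits: the limit of > 50000 nM in this assay, at which 2 of the 3 values shown sit.

The compounds shown leave open whether N-methylanilino or cyclohexylamino would tell which counted difference, the aromatic ring or the hydrogen-bond donor, goes with the loss. Also open, going by these compounds, is how piperidin-1-yl, or a 4-(cyclohexyl(methyl)amino)butyl chain, would read in this assay.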